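Turning the double bond of compound 2

The source may report more compounds than this note shows. Statements on the series, on what has been measured and on what is new or still open speak of the compounds shown alone.

Compound 1 `COc1cc(/C=C/c2ccc(C(C)C)cc2)cc(OC)c1OC`: 9.8 uM
Compound 2 `COc1cc(/C=C\c2ccc(C(C)(C)C)cc2)cc(OC)c1OC`: 1.02 uM

Among the measured compounds shown here, in a functional assay on A549 cells (Homo sapiens) for cytotoxicity (on this read-out lower numbers stand for an effect already at smaller amounts and higher numbers for an effect only at larger amounts of compound), compound 2 gives 1.02 uM, the lower of the two numbers measured so far. Compound 1 stands at 9.8 uM, a gap beyond the usual scatter of repeated measurements.

The next compound to be tested is compound 3 `COc1cc(/C=C/c2ccc(C(C)(C)C)cc2)cc(OC)c1OC`. Its relation to compound 2 is simple: the two compounds have the same atoms and bonds and differ only in configuration as drawn: 1 of 1 stereo elements differ; a double bond is drawn Z in compound 2 and E in compound 3. The two molecules therefore contain the same parts, and only the arrangement around that double bond changes.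

For the measured compounds named here, no measured pair shows this change on its own, so the expectation rests on thin evidence. Going by the values given here, the only clue is compound 1, which has its double bond drawn E and gives 9.8 uM. It differs from compound 2 in another place as well, so it is an imperfect guide, but it points towards a higher number. A rise beyond the scatter is expected in this assay, with an estimated 6.9-fold higher number from compound 2 to compound 3 (0.84 log units; beyond the scatter). For compound 3 the estimated value is 7 uM, with an expected range from 2.5 uM to 25 uM.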

Compound 3, concentration for half-maximal effect: > 25 uM
Compound 3 was reported as a limit; the forecaster's own chance of this, stated with the estimate: 10%; middle value at least 3.5-fold (0.55 log units) from the limit.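

In this assay there is an at least 24-fold higher number from compound 2 to compound 3 (1.38 log units; beyond the scatter), and this large step, which lies beyond the scatter, can be put down to the arrangement around the double bond alone: the fact that compounds 2 and 3 differ only in the configuration as drawn. Compound 3 gives > 25 uM, which is a limit of the assay and not a number. With the double bond drawn E in both compounds, methyl in place of hydrogen on a saturated chain carbon bound to an aromatic carbon and two saturated chain carbons gives an at least 2.5-fold higher number from compound 1 to compound 3 (0.40 log units; beyond the scatter), so this added methyl does not bring the number down towards the low value seen with the Z double bond.

As far as these compounds go, whether the same gap between the Z and E forms appears with an amine, a carboxylic acid or a longer chain in place of the branched chain stays open. From the compounds shown here alone, how far the true value of compound 3 lies past its limit also stays open, which leaves the full size of both steps unknown.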